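The source may report more compounds than this note shows. Statements on the series, on what has been measured and on what is new or still open speak of the compounds shown alone.

Measured so far in this series:
compound 1 `CCc1ccc(NC2=CC(=O)c3nc4n(c3C2=O)[C@H]2OC[C@@H](O)[C@H]2OC4)cc1` — 3080 nM
compound 2 `O=C1C(N2CCCC2)=CC(=O)c2c1nc1n2[C@H]2OC[C@@H](O)[C@H]2OC1` — > 16000 nM, a limit of the assay
compound 3 `O=C1C=C(NC2CCCC2)C(=O)c2c1nc1n2[C@H]2OC[C@@H](O)[C@H]2OC1` — > 16000 nM, a limit of the assay

In a functional assay on ECa-109 cells for inhibition, with ECa-109 cell line (Homo sapiens) as the target, read by sulforhodamine B assay (on this read-out lower numbers stand for stronger inhibition and higher numbers for weaker inhibition), compound 1 gives 3080 nM. Compound 2 stands at the limit of > 16000 nM in this assay, at which 2 of the 3 values shown sit, so no number is known for it. Compound 4 `O=C1C(Nc2cccc(Cl)c2)=CC(=O)c2c1nc1n2[C@H]2OC[C@@H](O)[C@H]2OC1` is not yet measured and differs from compound 2 by (3-chlorophenyl)amino in place of pyrrolidin-1-yl on a double-bonded ring carbon. Within the data shown here, the one measured step that bears on this is an at least 5.1-fold higher number from compound 1 to compound 3 (0.71 log units; beyond the scatter), where the amine nitrogen carrying a phenyl ring gave the lower number. Compound 4 carries such an amine, as in compound 1, while compound 2 does not. A downward step beyond the scatter is therefore expected for compound 4, an at least 4.0-fold lower number from compound 2 to compound 4 (0.60 log units; beyond the scatter). Compound 4 is estimated at 4000 nM, within 1500 nM to 12000 nM.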

Compound 4, half-maximal inhibitory concentration: 3080 nM
The estimate for compound 4 lay 1.3-fold (0.11 log units) above the measured number; the measured number falls inside the stated range.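

Among these compounds, on a double-bonded ring carbon, an at least 5.1-fold lower number from compound 2 to compound 4 (0.71 log units; beyond the scatter) in this assay gives the first measured step for an aromatic amine against a saturated ring amine on this form of the core. Together with an at least 5.1-fold higher number from compound 1 to compound 3 (0.71 log units; beyond the scatter), it gives two steps in the same direction, each favouring the aryl amine. The size of the new step is only a bound: the limit of > 16000 nM in this assay, at which 2 of the 4 values shown sit.

The change replaces the ring and adds the amine hydrogen in one step, so the two remain unseparated. Still open, on these data alone, are an unsubstituted phenylamino group, a 4-chlorophenylamino group and an open-chain amine such as diethylamino at this place.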